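Adding a second methoxy group: a small step expected

The source may hold more compounds than are shown below. What is called first, only, known or untested is meant among the compounds shown, and "the series" means these compounds.

Measured compounds in a functional assay on THP-1 cells (Homo sapiens) for inhibition, read by sulforhodamine B assay, tested at 100 uM; a lower number here means less inhibition of growth, a higher number more inhibition of growth at the concentration tested:
compound 1, `CC(=O)N1N=C(c2ccc(OCc3cn(Cc4ccc([N+](=O)[O-])cc4)nn3)cc2)CC1c1ccccc1`, gives 22%;
compound 2, `COc1ccc(C2CC(c3ccc(OCc4cn(Cc5ccc([N+](=O)[O-])cc5)nn4)cc3)=NN2C(C)=O)cc1`, gives 26%;
compound 3, `COc1ccc(C2=NN(C(C)=O)C(c3ccc(OCc4cn(Cc5ccc([N+](=O)[O-])cc5)nn4)c(OC)c3)C2)cc1`, gives 14%.

Compound 2 gives the highest of the three numbers shown. Going by the values given here, compound 1 lies within the usual scatter of it, compound 3 beyond it; no single-place step connects compound 3 to compound 2, so their two values are simply what they are.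

Compound 4, `COc1ccc(C2CC(c3ccc(OCc4cn(Cc5ccc([N+](=O)[O-])cc5)nn4)cc3)=NN2C(C)=O)cc1OC`, has not been measured. It differs from compound 2 in one place: methoxy in place of hydrogen on an aromatic carbon.

Among the compounds with values here, one measured step bears on this change. It is the same kind of change, a methoxy group in place of a hydrogen on an aromatic carbon, though on a different position of the ring: a number 4 percentage points higher from compound 1 to compound 2 (within the scatter). That step stayed within the scatter. Nothing in the data suggests that a further methoxy group would move the number more than that, so a step of no clear size beyond the scatter is expected in this assay, with a slight lean upward at most.

The estimated step from compound 2 to compound 4 is a number 1 percentage points lower from compound 2 to compound 4 (within the scatter). Compound 4 is therefore expected to give about 25%, with a range from 13% to 37%.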

Compound 4, percent growth inhibition at one concentration: 9%
For compound 4 the middle estimate is 16 percentage points above the measured one, outside the stated range (below it).
By their numbers in this assay, from the lowest: compounds 4, 3, 1 and 2 (each within the scatter of the next, the first and the last beyond it).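

In this assay, this place on the ring responds differently from the earlier one: the first methoxy group gave a number 4 percentage points higher from compound 1 to compound 2 (within the scatter), whereas a methoxy group ortho to that methoxy group, turning 4-methoxyphenyl into 3,4-dimethoxyphenyl, gives a number 17 percentage points lower from compound 2 to compound 4 (beyond the scatter). The same kind of change therefore cannot be carried from one ring position to another, and a small added group is enough to move this read-out beyond the scatter. Set against the plain phenyl of compound 1, the 3,4-dimethoxyphenyl group gives a number 13 percentage points lower from compound 1 to compound 4 (beyond the scatter), so the two methoxy groups together lower the number even though the first alone showed no clear change, and nothing available explains this drop.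

The compounds shown leave open whether the drop belongs to the methoxy group itself or would follow any group at this carbon, such as a hydroxy group, a fluorine atom or a longer ethoxy chain. Going by these compounds alone, they also leave open whether this methoxy group would lower the number without the first methoxy group on the same ring.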